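One Added Fluoro Group on Compound 1

The source may report more compounds than this note shows. Statements on the series, on what has been measured and on what is new or still open speak of the compounds shown alone.

Compound 1 `NC(=O)/C=C1\CCc2c(F)cccc21`: > 100 mg/kg
Compound 2 `O=C(/C=C1\CCc2ccccc21)NC1CC1`: 150 mg/kg
Compound 3 `O=C(/C=C1\CCc2cc(F)cc(F)c21)NC1CC1`: 69 mg/kg

In a functional assay on the whole organism with Mus musculus as the target (a lower number here means that less compound is needed, a higher number that more compound is needed for the effect), compound 1 reaches only a limit, > 100 mg/kg, and not a number.

Compound 4 `NC(=O)/C=C1\CCc2c(F)cc(F)cc21` differs from compound 1 by one change: fluoro in place of hydrogen on an aromatic carbon. A fluoro group replaces hydrogen on an aromatic carbon, meta to a fluoro group.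

Among the compounds with values here, no measured step isolates this change. Within the data shown here, the only guide is a different amide, compound 3, which has two fluoro groups and gives 69 mg/kg, whereas compound 2 has none and gives 150 mg/kg.

A modest shift toward less compound needed is expected, estimated as an at least 1.3-fold lower number from compound 1 to compound 4 (0.12 log units; that floor lies within the scatter).

Compound 4 is estimated at 75 mg/kg, with an expected range of 28 mg/kg to 200 mg/kg.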

Compound 4, dose for half-maximal effect: 69 mg/kg
Compound 4: middle estimate off by 1.1-fold (0.04 log units), on the high side; the range from low to high includes it.
By their numbers in this assay, from the lowest: compounds 3 and 4 (each within the scatter of the next); then compound 2.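

In this assay compound 1 gives > 100 mg/kg, which is a limit and not a number. Fluoro in place of hydrogen on this aromatic carbon, meta to a fluoro group, yields a measured value, and the change can be read as an at least 1.4-fold lower number from compound 1 to compound 4 (0.16 log units; that floor lies within the scatter). Only this floor can be read, and the real step may be larger, because the starting point is a limit: the limit of > 100 mg/kg in this assay, at which 1 of the 4 values shown sits.

The compounds shown leave open how far the change reaches beyond the scatter. They also leave open what a chloro or methoxy group would give on this same aromatic carbon.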